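The compounds below may be only part of what the source reports. "The series", "measured", "known", "first", "only" and "open" are said of these compounds alone.

Measured compounds in the series:
compound 1, `CC(=O)Nc1cccc(-c2ccc(C(=O)N(Cc3cccc(OCCCCCC(=O)O)c3)C(C)C)cc2)c1`, with > 26000 nM
compound 2, `Cc1nnc(-c2cccc(-c3ccc(C(=O)N(Cc4cccc(OCCCCCC(=O)O)c4)C(C)C)cc3)c2)o1`, with > 26000 nM
compound 3, `CC(C)N(Cc1cccc(OCCCCCC(=O)O)c1)C(=O)c1ccc(-c2cccc(O)c2)cc1`, with > 26000 nM

In an ADME assay on Raji cells (Homo sapiens) for cytotoxicity, read by CellTiter-Glo and resazurin assay, with a stated time of 72 h (a lower number here means that less compound is needed, a higher number that more compound is needed for the effect), compound 1 stands only at a limit of the assay, > 26000 nM, and not at a number. Compound 2 likewise sits at a limit, > 26000 nM. Compound 3 too reaches only a limit, > 26000 nM. All three therefore share one position: the limit of > 26000 nM in this assay, at which 3 of the 3 values shown sit. The step that the two limits leave unreadable from compound 1 to compound 2 cannot be read because both ends are limits, and the same holds for a step that the two limits leave unreadable from compound 1 to compound 3 and for a step that the two limits leave unreadable from compound 2 to compound 3.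

The piece now follows compound 1 to compound 4, `CC(C)N(Cc1cccc(OCCCCCC(=O)O)c1)C(=O)c1ccc(-c2cccc(OC(F)(F)F)c2)cc1`. The change is trifluoromethoxy in place of acetamido on an aromatic carbon. Among the measured compounds shown here, the steps that bear on it are those from compound 1 to compound 2 and from compound 1 to compound 3, in which acetamido was also exchanged on that aromatic carbon, and both left the readout at the same limit. Nothing in the three values shown gives a direction, so no step beyond the scatter is expected in this assay, and a fourth limit seems the likeliest outcome. For compound 4 the expected value is 30000 nM, with a range from 15000 nM to 80000 nM. The estimated step from compound 1 is expected to be a step that the limit leaves unreadable from compound 1 to compound 4.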

Compound 4, half-maximal effective concentration: > 26000 nM
Compound 4 was reported as a limit; the forecaster's own chance of this, stated with the estimate: 85%; the middle value lies beyond the limit too.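

Compound 4 is reported in this assay only as a limit, > 26000 nM, so its steps to compound 1, compound 2 and compound 3 cannot be read, because all four compounds share one position: the limit of > 26000 nM in this assay, at which 4 of the 4 values shown sit.

The compounds shown leave open how far apart these four lie in this assay, and whether any exchange on that aromatic carbon would give a measured number.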